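The compounds below may be only part of what the source reports. "The series", "measured", "known", "first", "only" and "open" are said of these compounds alone.

Measured so far:
- compound 1 `CC(=O)Nc1nc2ccc(-c3cn([C@@H]4CN[C@H](C(=O)Nc5ccc(Cl)cc5Cl)C4)nn3)nc2s1`: 36.1%
- compound 2 `Nc1nc2ccc(-c3cn([C@@H]4CN[C@H](C(=O)Nc5ccc(F)c(F)c5)C4)nn3)nc2s1`: 27.4%

Both numbers come from a functional assay on K562/Adr cells (Homo sapiens) for inhibition, read by MTT assay, with a stated time of 48 h, tested at 30 uM; on this read-out higher numbers stand for more inhibition at the one concentration tested (going by the name of the read-out) and lower numbers for less inhibition. In this assay compound 2 gives 27.4% and compound 1 gives 36.1%; the two values lie within the scatter of each other, so nothing can be read from their order. Within the data shown here, compound 1 and compound 2 differ in two places at once, at the amide aryl group and at the nitrogen on the aromatic ring of the shared core, so no single step between them is defined.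

Compound 3 `CC(=O)Nc1nc2ccc(-c3cn([C@@H]4CN[C@H](C(=O)Nc5ccc(F)c(F)c5)C4)nn3)nc2s1` keeps the difluorophenyl amide of compound 2 and carries the change (acetyl in place of hydrogen on a nitrogen on an aromatic ring). Compound 3 thus has the same acetamido group as compound 1, but whether that group by itself moves the read-out cannot be separated from the data at hand. With compound 1 at 36.1% and compound 2 at 27.4% lying within the scatter, the step from compound 2 to compound 3 is expected to be small, with no direction beyond the scatter: a number 3.6 percentage points higher from compound 2 to compound 3 (within the scatter) is the expected step. For compound 3 in this assay the estimate is 31%, with a range from 18% to 44%.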

Compound 3, a percentage reported as inhibition, at one concentration (the size of the read-out at that concentration, not a potency): 38.4%
Estimate against measurement, compound 3: 7.4 percentage points below; measured number inside the range.
By their numbers in this assay, from the lowest: compounds 2, 1 and 3 (each within the scatter of the next, the first and the last beyond it).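

In this assay, among these compounds, with the 3,4-difluorophenyl amide held fixed, acetyl in place of hydrogen on a nitrogen on an aromatic ring gives a number 11 percentage points higher from compound 2 to compound 3 (beyond the scatter), the first reading of a single change at this nitrogen, and a modest one. With the acetamido group held fixed, 3,4-difluorophenyl in place of 2,4-dichlorophenyl on an amide-type nitrogen gives a number 2.3 percentage points higher from compound 1 to compound 3 (within the scatter), so no effect of this exchange at the amide can be read at the one concentration tested. Nothing at hand speaks to what lies behind the step from amino to acetamido.

From the compounds shown here alone, the amino and acetamido groups are paired only on the 3,4-difluorophenyl amide here, so it remains open whether the step carries over to the 2,4-dichlorophenyl amide or to other amide aryl groups. Also open, going by these compounds, is whether the step belongs to the acetyl group alone or extends to other groups on this nitrogen, such as a propionyl group with its longer chain, a methanesulfonyl group or a methylurea.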